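The source may report more compounds than this note shows. Statements on the series, on what has been measured and on what is new or still open speak of the compounds shown alone.

Measured so far in an assay on HEK293 cells for positive allosteric modulation of metabotropic glutamate receptor 2 (Rattus norvegicus), read by thallium flux, with a stated time of 2.5 min; a lower number here means a smaller maximal response, a higher number a larger maximal response:
- compound 1, `Cc1c(OCCCCOc2ccccc2C(=O)O)ccc(C(=O)CC2CCCC2)c1C`: 67.1%
- compound 2, `Cc1c(OCCCCOc2ccccc2C(=O)O)ccc(C(=O)CC2CCCC2)c1O`: 98.8%
- compound 3, `Cc1c(OCCCCOc2ccc(C(=O)O)cc2)ccc(C(=O)CC(C)C)c1O`: 88%

Compound 2 stands highest of the three, with compound 3 nearest and compound 1 furthest. Among the compounds with values here, the only single-point step in the set, a number 31.7 percentage points higher from compound 1 to compound 2 (beyond the scatter), concerns a hydroxy in place of a methyl and does not touch the carboxyphenyl end. Compound 4, `Cc1c(OCCCCOc2ccc(C(=O)O)c(Cl)c2)ccc(C(=O)CC2CCCC2)c1O`, differs from compound 2 in one place: 4-carboxy-3-chlorophenyl in place of 2-carboxyphenyl on an oxygen on a saturated carbon. Within the data shown here, no measured step covers this change; compound 3, which also carries a carboxy moved from the 2-position to the 4-position but differs elsewhere as well, gives 88% against compound 2. On that thin basis compound 4 is expected at 88%, range 70% to 105%, a step of a number 10.8 percentage points lower from compound 2 to compound 4 (beyond the scatter) that may not exceed the scatter.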

Compound 4, largest response reached (reported as percent of maximum), in percent of the reference or control that the assay uses: 80.8%
Estimate against measurement, compound 4: 7.2 percentage points above, within the range that was stated.
By their numbers in this assay, from the lowest: compound 1; then compounds 4 and 3 (each within the scatter of the next); then compound 2.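

In this assay, within the data shown here, the step from the 2-carboxyphenyl to the 4-carboxy-3-chlorophenyl group gives a number 18 percentage points lower from compound 2 to compound 4 (beyond the scatter), the first single-place reading at this end of the molecule. The aryl group on this oxygen therefore affects the maximal response, yet compound 4 still reaches 80.8% with the new group in place. No evidence at hand accounts for the step.

The change moves the carboxy group and adds a chlorine at once, so the step cannot be divided between the two. As far as these compounds go, the effect of a bromine in place of the chlorine, or of an amide in place of the carboxylic acid, remains open.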